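A few compounds are considered here, and "the series" means these few. Any claim that something is new, unique, unknown or untested is made for them only; others in the source may bear on it.

Of the compounds shown here, two have so far been measured in a functional assay on MCF7 cells (Homo sapiens) for inhibition, read by MTT assay; a lower number here means a stronger inhibitor, a higher number a weaker inhibitor. Compound 1, `O=C(COc1ccc(C(=O)/C=C/c2ccccc2)cc1)NO`, gives 620 nM in this assay. Compound 2, `O=C(CCCN1CCN(C(=O)Nc2cccc3ncccc23)CC1)NO`, gives 7190 nM in this assay. Compound 1 holds the lower of the two numbers, and the gap to compound 2 lies beyond the usual scatter; the two structures differ in many places at once, so no single change can be weighed from them.

Compound 3, `O=C(COc1ccc(C(=O)/C=C/c2ccc(F)cc2)cc1)NO`, is not yet measured. It differs from compound 1 in one place: fluoro in place of hydrogen on an aromatic carbon. A hydrogen leaves and fluoro enters on an aromatic carbon of a six-membered aromatic ring of carbon only; read one bond further out, phenyl becomes 4-fluorophenyl. Nothing measured here tells what such a change does, and a change of one heavy atom is expected to shift the number only a little, in no settled direction, within the scatter. Compound 3 is therefore estimated at 550 nM, between 250 nM and 1300 nM, and the expected step of a 1.1-fold lower number from compound 1 to compound 3 (0.05 log units; within the scatter) should stay within the scatter.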

Compound 3, half-maximal inhibitory concentration: 620 nM
The estimate for compound 3 lay 1.1-fold (0.05 log units) below the measured number; measured number inside the range.
By their numbers in this assay, from the lowest: compounds 1 and 3 (each within the scatter of the next); then compound 2.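

In this assay, within the data shown here, replacing phenyl with 4-fluorophenyl shows no change at the digits printed from compound 1 to compound 3 (within the scatter), and this is the first step here that alters a single place, so one change can finally be weighed on its own. On this aromatic carbon, para to a large group, fluoro in place of hydrogen leaves the reading within the scatter, so this one-atom replacement brings no visible gain or loss in this assay. No supporting measurement bears on what the fluoro does at this carbon, so the unchanged number stands as an observation without an explanation.

As far as these compounds go, one fluoro is only a single case, so it remains open whether a methoxy group, an amine or a carboxylic acid on the same carbon would also keep the number within the scatter or would move it beyond the scatter in either direction. Also open, from the compounds shown here alone, is whether fluoro on another carbon of this ring would read the same, and whether a longer chain elsewhere in the core of compound 1 would shift the number.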